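Methoxy in place of chloro on the shared core

This account rests on a few compounds, and the source may have more. Where it says the series, first, only, none or still open, it means among the compounds named here.

Measured in an ADME assay on CCRF-CEM cells (Homo sapiens) for cytotoxicity, read by cell counting, with a stated time of 72 h (a higher number here means that more compound is tolerated, a lower number that less compound is tolerated), so far
compound 1 `Nc1nc(O)c2ncn(CSC(CO)CO)c2n1` gives > 500000 nM as a limit
compound 2 `Nc1nc(Cl)c2ncn(CCC(CO)CO)c2n1` gives 400000 nM as a number

Among the measured compounds shown here, compound 2 stands at 400000 nM in this assay and holds the only numeric reading. The reading of compound 1 is a limit, given as > 500000 nM by the assay. Compound 3 `COc1nc(N)nc2c1ncn2CCC(CO)CO` carries methoxy in place of chloro on an aromatic carbon, next to the ring nitrogen methoxy in place of chloro on an aromatic carbon and is still unmeasured. For the measured compounds named here, no measured step between compounds sizes this change. In this assay the expected no change at the digits printed from compound 2 to compound 3 (within the scatter) stays within the usual scatter and has no expected direction. That expectation rests on compound 2 at 400000 nM and on the modest size of the exchange. The estimate for compound 3 is 400000 nM with an expected range of 180000 nM to 800000 nM for a numeric result.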

Compound 3, half-maximal cytotoxic concentration: 246000 nM
Estimate against measurement, compound 3: 1.6-fold (0.21 log units) above; measured number inside the range.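

Methoxy in place of chloro on an aromatic carbon, next to the ring nitrogen, gives the first readable step in the series in this assay: a 1.6-fold lower number from compound 2 to compound 3 (0.21 log units; within the scatter). This single pair shows that exchanging chlorine for the two heavy atoms of methoxy, with one hydrogen-bond acceptor entering, does not move the reading beyond the scatter, so the chloro group is not required for a reading of this size. Compound 1 carries a limit rather than a number and differs from compound 2 in more than one place, so it stays outside this comparison: the limit of > 500000 nM in this assay, at which 1 of the 3 values shown sits.

On these data alone, whether the same holds for an amine or a longer alkoxy chain at this position remains open. One step also cannot show how far this position tolerates exchange on other side chains of the shared core.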